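Working notes: from compound 1 to compound 3

The source may report more compounds than this note shows. Statements on the series, on what has been measured and on what is new or still open speak of the compounds shown alone.

Measured in a physicochemical assay for solubility, with a stated time of 24 h, at pH 4.5; on this read-out higher numbers stand for higher solubility and lower numbers for lower solubility:
- compound 1 `O=C(NC[C@@H]1[C@H]2CN(C(=O)/C=C/c3cc(Cl)cc(Cl)c3)C[C@@H]12)c1ccc2[nH]c(=O)oc2c1` gives < 1 ug/mL, a limit
- compound 2 `O=C(NC[C@@H]1[C@H]2CN(C(=O)OCc3cc(C(F)(F)F)cc(C(F)(F)F)c3)C[C@@H]12)c1ccc2[nH]c(=O)oc2c1` gives < 1 ug/mL, a limit

Compound 1 has no number in this assay, only the limit < 1 ug/mL. The same holds for both measured compounds: the limit of < 1 ug/mL in this assay, at which 2 of the 2 values shown sit. No order can be read from them.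

Compound 3 `Cc1ccc(COC(=O)N2C[C@@H]3[C@@H](CNC(=O)c4ccc5[nH]c(=O)oc5c4)[C@@H]3C2)nc1` keeps the core of compound 1. On a carbonyl carbon whose other neighbours are an amide-type nitrogen in a ring, the 2-(3,5-dichlorophenyl)ethenyl group gives way to a group with a six-membered aromatic ring with 1 hetero atom: a group of 9 heavy atoms (7 carbon, 1 nitrogen, 1 oxygen; one six-membered aromatic ring with 1 hetero atom) in place of a group of 10 heavy atoms (8 carbon, 2 chlorine; one six-membered aromatic ring of carbon only), on a carbonyl carbon.

No measured step sizes this change, so the expectation rests on the structural change alone. An upward step beyond the scatter in this assay is expected, estimated as an at least 20-fold higher number from compound 1 to compound 3 (1.30 log units; beyond the scatter). For compound 3 the estimate is 20 ug/mL, with an expected range of 3 ug/mL to 150 ug/mL.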

Compound 3, solubility: 66 ug/mL
The estimate for compound 3 lay 3.3-fold (0.52 log units) below the measured number, and the stated range covers the measured number.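

Among the compounds shown here, compound 3 is the first compound here to give a number rather than a limit in this assay, which shows that the group on the carbonyl carbon whose other neighbours are an amide-type nitrogen in a ring can shift this read-out while the shared core stays the same. Replacing the 2-(3,5-dichlorophenyl)ethenyl group gives an at least 66-fold higher number from compound 1 to compound 3 (1.81 log units; beyond the scatter). That step marks only a minimum, and its full size cannot be read because the starting point is a limit: the limit of < 1 ug/mL in this assay, at which 2 of the 3 values shown sit.

For the compounds shown here, the single step changes the ring hetero atom, the chlorine atoms and the double bond together, so their separate shares remain open. As far as these compounds go, it is also open how this read-out would respond to an amine or a carboxylic acid on the entering group.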